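Chain terminus of a piperidine benzamide: hydroxy to phthalimide

This account rests on a few compounds, and the source may have more. Where it says the series, first, only, none or still open, it means among the compounds named here.

Compound 1 `CCN1CCC(NC(=O)c2cc(Cl)c(N)cc2OC)CC1` gives 1000 nM in an assay on HEK293 cells for displacement of a labelled ligand from 5-hydroxytryptamine receptor 4 (Homo sapiens), read by scintillation counting; on this read-out higher numbers stand for weaker inhibition and lower numbers for stronger inhibition. Compound 2 `CCCCCN1CCC(NC(=O)c2cc(Cl)c(N)cc2OC)CC1` gives 100 nM. Compound 3 `COc1cc(N)c(Cl)cc1C(=O)NC1CCN(CCCCCO)CC1` gives 63.1 nM.

Compound 3 has the lowest number of the three; compound 2 lies within the scatter of it, compound 1 well beyond. The steps of a 10-fold lower number from compound 1 to compound 2 (1.00 log units; beyond the scatter) and a 16-fold lower number from compound 1 to compound 3 (1.20 log units; beyond the scatter) show the longer chain helping, while a 1.6-fold lower number from compound 2 to compound 3 (0.20 log units; within the scatter) shows the terminal hydroxy changing little. Compound 4 `COc1cc(N)c(Cl)cc1C(=O)NC1CCN(CCCCCN2C(=O)c3ccccc3C2=O)CC1` differs from compound 3 in a group of 11 heavy atoms (8 carbon, 1 nitrogen, 2 oxygen; one five-membered non-aromatic ring with 1 hetero atom, one six-membered aromatic ring of carbon only) in place of one oxygen atom, on a saturated chain carbon, five bonds along the chain from an amine nitrogen in a ring. For the measured compounds named here, no measured step covers such a group; the chain itself is kept, so compound 4 is expected to stay at or below the level of compound 2, with a 2.5-fold lower number from compound 3 to compound 4 (0.40 log units; beyond the scatter) estimated. Compound 4 is expected near 25 nM, within 5 nM to 125 nM.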

Compound 4, inhibition constant: 20 nM
The estimate for compound 4 lay 1.3-fold (0.10 log units) above the measured number; the measured number falls inside the stated range.
By their numbers in this assay, from the lowest: compound 4; then compounds 3 and 2 (each within the scatter of the next); then compound 1.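

Compound 4 shows that this place, on a saturated chain carbon five bonds along the chain from an amine nitrogen in a ring, accepts a far larger group than hydroxy, with a 3.2-fold lower number from compound 3 to compound 4 (0.50 log units; beyond the scatter) and a 5.0-fold lower number from compound 2 to compound 4 (0.70 log units; beyond the scatter). Unlike the hydroxy, this terminal group moves the number beyond the scatter, and it does so with 0 hydrogen-bond donors. Nothing available explains this shift.

Whether the six-membered aromatic ring or the carbonyls account for the step remains open. So does how a terminal amine, a carboxylic acid or a longer chain would read.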